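The source may report more compounds than this note shows. Statements on the series, on what has been measured and on what is new or still open speak of the compounds shown alone.

The set comprises three measured compounds and one that has not yet been tested, all assessed in a functional assay on VCaP cells (Homo sapiens) for antiproliferative activity, read by fluorescence and propidium iodide staining, with a stated time of 96 h; a lower number here means a stronger inhibitor, a higher number a weaker inhibitor. Compound 1 `O=C(Nc1cc(C(F)(F)F)cc(C(F)(F)F)c1)c1ccc(Sc2ccc(O)cc2)cc1` gives 2590 nM in this assay. Compound 3 `O=C(Nc1cc(C(F)(F)F)cc(C(F)(F)F)c1)c1ccc(S(=O)(=O)c2ccc(O)cc2)cc1` differs from compound 1 by (4-hydroxyphenyl)sulfonyl in place of (4-hydroxyphenyl)sulfanyl on an aromatic carbon, and compound 3 gives 9720 nM, a step of a 3.8-fold higher number from compound 1 to compound 3 (0.57 log units; beyond the scatter). Compound 2 `O=C(Nc1cccc(S(F)(F)(F)(F)F)c1)c1ccc(Sc2ccc(O)cc2)cc1` keeps the (4-hydroxyphenyl)sulfanyl group of compound 1 but differs elsewhere; the difference between the two cores is not broken down here. In this assay compound 2 gives 6100 nM, a value that lies within the scatter of compound 3 and beyond the scatter of compound 1.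

Compound 4 `O=C(Nc1cccc(S(F)(F)(F)(F)F)c1)c1ccc(S(=O)(=O)c2ccc(O)cc2)cc1` stands to compound 2 as compound 3 stands to compound 1: the change is (4-hydroxyphenyl)sulfonyl in place of (4-hydroxyphenyl)sulfanyl on an aromatic carbon, at the same place, so it is the same change. Among the measured compounds shown here, because the single earlier instance gave a 3.8-fold higher number from compound 1 to compound 3 (0.57 log units; beyond the scatter), the step from compound 2 to compound 4 is expected to be about a 3.8-fold higher number from compound 2 to compound 4 (0.58 log units; beyond the scatter), taken as roughly the same size, with the caveat that this rests on one pair only and that the change is here applied to a different core. On that basis compound 4 is expected to give about 23000 nM in this assay, most likely falling between 10000 nM and 50000 nM. A number this high may approach where this assay reports only a limit.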

Compound 4, half-maximal inhibitory concentration: 10800 nM
Compound 4: middle estimate off by 2.1-fold (0.33 log units), on the high side; the measured number falls inside the stated range.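

In this assay, placing the (4-hydroxyphenyl)sulfonyl group where the core of compound 2 carries the (4-hydroxyphenyl)sulfanyl group gives a 1.8-fold higher number from compound 2 to compound 4 (0.25 log units; within the scatter), so on this core the change does not clearly separate the two compounds. Set beside the earlier pair, the step on this core cannot be told apart in size from the step on the core of compound 1: the same change on two cores in this assay, a 3.8-fold higher number (0.57 log units; beyond the scatter) from compound 1 to compound 3 and a 1.8-fold higher number (0.25 log units; within the scatter) from compound 2 to compound 4, 2.1-fold (0.33 log units) apart, within the scatter of two such steps. Among the compounds shown here, this is consistent with the change carrying over from one core to the other at a similar size, but it does not establish a fixed size, since only two pairs are available, only one of the two steps lies beyond the scatter, and neither pair says how the change would behave on any further core.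

The compounds shown leave open what happens when the sulfur link gives way to a sulfinyl group, an ether oxygen or an amine, and whether the same step appears when the hydroxyl on the 4-hydroxyphenyl ring is replaced by a methoxy group or a carboxylic acid. They also leave open whether the step would hold on a core bearing a group other than the two trifluoromethyl groups of compound 1 or the pentafluorosulfanyl group of compound 2.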